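Trimming the Propargyl Chain of Compound 2

This account rests on a few compounds, and the source may have more. Where it says the series, first, only, none or still open, it means among the compounds named here.

Of the compounds shown here, two sharing a core have so far been tested in a functional assay on B16 cells (Mus musculus) for cytotoxicity, read by sulforhodamine B assay, with a stated time of 72 h; a higher number here means a weaker inhibitor, a lower number a stronger inhibitor. Compound 1, `C#CCSc1cnc2ccccc2c1[Se]CC#CCBr`, gives 4.2 ug/mL. Compound 2, `C#CCSc1cnc2ccccc2c1SCC#CCO`, gives 54.7 ug/mL, the higher of the two numbers and so the weaker inhibitor. Among the measured compounds shown here, the one step measured so far, a 13-fold higher number from compound 1 to compound 2 (1.11 log units; beyond the scatter), concerns a different part of the molecule, the selenium-bearing side chain. Compound 3, `CSc1cnc2ccccc2c1SCC#CCO`, differs from compound 2 by hydrogen in place of ethynyl on a saturated chain carbon bound to a sulfur. For the measured compounds named here, no measured step touches this position, so the numbers at hand give no guide to its effect, and the safest expectation is a change no larger than the usual scatter. Compound 3 is therefore estimated at 60 ug/mL, within a range of 25 ug/mL to 140 ug/mL. That estimate means a 1.1-fold higher number from compound 2 to compound 3 (0.04 log units; within the scatter), expected to fall inside the ordinary spread of repeat measurements.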

Compound 3, concentration for 50% inhibition: 49.8 ug/mL
The estimate for compound 3 lay 1.2-fold (0.08 log units) above the measured number; the range from low to high includes it.
By their numbers in this assay, from the lowest: compound 1; then compounds 3 and 2 (each within the scatter of the next).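

Replacing ethynyl with hydrogen on a saturated chain carbon bound to a sulfur gives a 1.1-fold lower number from compound 2 to compound 3 (0.04 log units; within the scatter) in this assay and so gives this position its first reading, since the earlier step concerned the other side chain. For this pair, propargylsulfanyl and methylsulfanyl cannot be told apart by their numbers, which means the triple bond of the propargyl group can be lost here without a change that stands out from repeat measurements. Nothing available explains why the two compounds read alike.

Going by these compounds, it remains open whether a longer chain in place of the methyl, or an amine or a carboxylic acid on that saturated chain carbon, would move the number. On these data alone, it is also open whether the same change would read alike with the selenium-bearing side chain of compound 1 in place.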